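Hydrazone series: aryl swap on the hydrazine nitrogen

A few compounds are considered here, and "the series" means these few. Any claim that something is new, unique, unknown or untested is made for them only; others in the source may bear on it.

Compound 1 `CC1CC/C(=N\Nc2ccc(Br)cc2)c2ncc(C(=O)O)c(=O)n21` in a functional assay on the whole organism for inhibition, with Rattus norvegicus as the target (on this read-out higher numbers stand for an effect only at larger amounts of compound and lower numbers for an effect already at smaller amounts), gives a limit, > 1000 umol/kg.
Compound 2 `CC1CC/C(=N\Nc2ccccc2O)c2ncc(C(=O)O)c(=O)n21` in this assay gives a limit, > 100 umol/kg.

Both measured compounds stop at a limit of this assay, so neither has a number. Among the compounds with values here, the only measured step, a step that the two limits leave unreadable from compound 1 to compound 2, cannot be read, because the two ends are limits the limit of > 100 umol/kg in this assay, at which 1 of the 2 values shown sits, and (the limit of > 1000 umol/kg in this assay, at which 1 of the 2 values shown sits). Within the data shown here, compound 2 thus stands at a limit, with the one other value shown also a limit.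

Compound 3 `COc1ccc(N/N=C2\CCC(C)n3c2ncc(C(=O)O)c3=O)cc1` is not yet measured in this assay. It differs from compound 2 by 4-methoxyphenyl in place of 2-hydroxyphenyl on an amine nitrogen. Among the measured compounds shown here, no measured step covers an aryl swap of this kind, so nothing shows whether the change moves the read-out beyond the scatter, in either direction. With compound 2 at a limit, compound 3 is expected to land near the same range, with the step that the limit leaves unreadable from compound 2 to compound 3 taken as no change beyond the scatter. The estimate for compound 3 is 300 umol/kg, between 30 umol/kg and 3000 umol/kg, most likely reported again as a limit.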

Compound 3, dose for 50% inhibition: 7.6 umol/kg
Estimate against measurement, compound 3: 39-fold (1.60 log units) above; measured number below the stated range.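

The aryl group on the amine nitrogen can decide the read-out in this assay: 4-methoxyphenyl in place of 2-hydroxyphenyl gives an at least 13-fold lower number from compound 2 to compound 3 (1.11 log units; beyond the scatter). The 4-substituted phenyl alone does not account for this, since methoxy in place of bromo on an aromatic carbon gives an at least 130-fold lower number from compound 1 to compound 3 (2.11 log units; beyond the scatter). Both steps start from a limit and so give only a minimum size, and nothing shown points to a cause for either.

Going by these compounds, it remains open whether the step from compound 2 belongs to the methoxy group or to where the oxygen sits on the phenyl ring, a question that a 4-hydroxyphenyl or a 2-methoxyphenyl compound would separate. On these data alone, how much room the 4-substituent allows is also open, and an ethoxy or a dimethylamino group there would test it.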